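This account rests on a few compounds, and the source may have more. Where it says the series, first, only, none or still open, it means among the compounds named here.

Measured compounds:
- compound 1, `CCCOC(=O)Nc1ccc([Se]C#N)cc1`, 75400 nM
- compound 2, `O=C(Nc1ccc([Se][Se]c2ccc(NC(=O)OCc3ccccc3)cc2)cc1)OCc1ccccc1`, 69000 nM
- compound 3, `Cc1ccc(OC(=O)Nc2ccc([Se][Se]c3ccc(NC(=O)Oc4ccc(C)cc4)cc3)cc2)cc1`, 70900 nM

All three were tested in a functional assay on HT-29 cells (Homo sapiens) for cytotoxicity, read by MTT assay, with a stated time of 72 h; on this read-out higher numbers stand for lower toxicity in this test and lower numbers for higher toxicity in this test. Compound 1 returns the highest of the three numbers, but its gap to compound 3 and to compound 2 lies within the scatter of the measurement, so the three compounds cannot be told apart on this read-out. Going by the values given here, no step between compounds that differ in one place is available among them, and compound 2 and compound 3 share a core quite different from that of compound 1, so their values say nothing about the carbamate chain.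

Compound 4, `CCCCCCOC(=O)Nc1ccc([Se]C#N)cc1`, has not yet been measured. It differs from compound 1 by propyl in place of hydrogen on a saturated chain carbon, three bonds along the chain from an oxygen next to a carbonyl group; cut one bond further out, the same difference reads propyl to hexyl. Among the compounds with values here, with no comparable step in hand, the account expects a 1.4-fold lower number from compound 1 to compound 4 (0.14 log units; within the scatter), a step that is not beyond the scatter, since the three known values in this assay sit close together and the change adds only a longer saturated chain. Compound 4 is therefore estimated at 55000 nM, with a range from 20000 nM to 150000 nM.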

Compound 4, concentration lethal to 50% of the cells: 69900 nM
The estimate for compound 4 lay 1.3-fold (0.10 log units) below the measured number, and the stated range covers the measured number.
By their numbers in this assay, from the lowest: compounds 2, 4, 3 and 1 (each within the scatter of the next).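

Propyl in place of hydrogen on a saturated chain carbon, three bonds along the chain from an oxygen next to a carbonyl group, gives the first comparison in this set of compounds that differ in one place, and in this assay it reads a 1.1-fold lower number from compound 1 to compound 4 (0.03 log units; within the scatter). Going by these compounds alone, at this position, propyl and hexyl therefore cannot be told apart on this read-out, something the earlier compounds could not show, since no step linked any of them and compound 2 and compound 3 carry a different core. Nothing measured here offers an explanation for this result.

Still open, from the compounds shown here alone, is whether a chain shorter than propyl, a chain longer than hexyl, or a chain ending in an amine or a carboxylic acid would give a number beyond the scatter at this position. Also open is whether a phenyl ring in place of the chain on the core of compound 1 would read any differently, as the single step shown covers only a change between two saturated chains.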